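Chloro to Methoxy: Expected Cytotoxicity of Compound 4

A few compounds are considered here, and "the series" means these few. Any claim that something is new, unique, unknown or untested is made for them only; others in the source may bear on it.

Of the compounds shown here, three share a core and have been tested in an ADME assay on Vero cells (Chlorocebus sabaeus) for cytotoxicity, read by MTT assay, with a stated time of 48 h; on this read-out higher numbers stand for lower toxicity in this test and lower numbers for higher toxicity in this test. Compound 1 `CC(C)(NC(=O)c1ccc([N+](=O)[O-])o1)c1ccc(Cl)cc1` gives 81000 nM. Compound 2 `COc1ccc(C(C)(C)NC(=O)c2ccc([N+](=O)[O-])o2)cc1` gives 82000 nM, and compound 3 `CC(C)(NC(=O)c1ccc([N+](=O)[O-])o1)c1ccc(COc2ccc(Cl)cc2)cc1` gives 120000 nM. The three numbers sit close together: a 1.0-fold higher number from compound 1 to compound 2 (0.01 log units; within the scatter), a 1.5-fold higher number from compound 1 to compound 3 (0.17 log units; within the scatter), and a 1.5-fold higher number from compound 2 to compound 3 (0.17 log units; within the scatter).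

Compound 1 and compound 2 differ in one place, (methoxy in place of chloro on an aromatic carbon). The same change turns compound 3 into compound 4 `COc1ccc(OCc2ccc(C(C)(C)NC(=O)c3ccc([N+](=O)[O-])o3)cc2)cc1`, which has not yet been tested: methoxy in place of chloro on an aromatic carbon. The two cores on which this change is made differ from each other by (4-chlorophenoxy)methyl in place of chloro on an aromatic carbon. The place of the change is described in the same words for both pairs, so this can be called the same change made on two different cores.

In this assay the change from compound 1 to compound 2 left the number essentially where it was, within the scatter of repeated measurements. There is no sign among these three compounds that the larger substituent of compound 3 behaves differently in this respect. For compound 4 the expected step is no change at the digits printed from compound 3 to compound 4 (within the scatter), because a 1.0-fold higher number from compound 1 to compound 2 (0.01 log units; within the scatter) shows the same change making almost no difference. Compound 4 is therefore estimated at 120000 nM in this assay, with a plausible range from 60000 nM to 240000 nM.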

Compound 4, half-maximal cytotoxic concentration: > 120000 nM
Compound 4: only a limit was reported; the forecaster's own chance of this, stated with the estimate: 25%; the middle value sits exactly at the limit.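

For compound 4 the result in this assay is a limit and not a number: the limit of > 120000 nM in this assay, at which 1 of the 4 values shown sits. The new step reads a number no lower from compound 3 to compound 4 (the limit leaves the size open) and so its size cannot be read, and the comparison of the methoxy-for-chloro change on the two cores stays unsettled: the same change on two cores in this assay, a 1.0-fold higher number (0.01 log units; within the scatter) from compound 1 to compound 2 and a number no lower (the limit leaves the size open) from compound 3 to compound 4; the limit leaves it open whether they differ The other two new steps give only floors, an at least 1.4-fold higher number from compound 2 to compound 4 (0.16 log units; that floor lies within the scatter) and an at least 1.4-fold higher number from compound 1 to compound 4 (0.17 log units; that floor lies within the scatter), so the result is compatible with the change carrying over unaltered to the larger core, yet it does not show this and does not exclude a larger rise on that core.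

The compounds shown hold only chloro or methoxy at this place on the aromatic ring, which leaves open whether a nitrile, an amine or a carboxylic acid there would also leave the number essentially unchanged. Among these compounds, they also cover only two cores, one with the group on the ring directly and one with it carried on the longer phenoxymethyl arm, so it remains open how the change would behave on a core with a longer chain or with an amine in that arm.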